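Compound 4: 2-fluorophenyl replacing 3-chlorophenyl on the amine nitrogen

A few compounds are considered here, and "the series" means these few. Any claim that something is new, unique, unknown or untested is made for them only; others in the source may bear on it.

For the measured compounds named here, in a functional assay on B16-F10 cells (Mus musculus) for inhibition, read by MTT assay, with a stated time of 72 h (a lower number here means a stronger inhibitor, a higher number a weaker inhibitor), compound 3 `N#Cc1c(Nc2cccc(Cl)c2)nc(SCc2cn(Cc3ccccc3Cl)nn2)nc1-c1ccccc1` gives 3590 nM, the lowest number among the three measured so far. Compound 2 `COc1ccc(Nc2nc(SCc3cn(Cc4ccccc4Cl)nn3)nc(-c3ccccc3)c2C#N)cc1` gives 3990 nM, which lies within the scatter of compound 3. Compound 1 `C#CCSc1nc(Nc2cccc(Cl)c2)c(C#N)c(-c2ccccc2)n1` gives 10500 nM, a gap from compound 3 that is beyond the scatter; compound 1 differs from compound 3 in more than one place, so its value only shows the spread of the series and nothing about any single change.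

Going by the values given here, the one single-point step measured is a 1.1-fold lower number from compound 2 to compound 3 (0.05 log units; within the scatter). It exchanged the aryl group on the nitrogen on the aromatic ring and left the number where it was.

Compound 4 `N#Cc1c(Nc2ccccc2F)nc(SCc2cn(Cc3ccccc3Cl)nn2)nc1-c1ccccc1` is the next single change: 2-fluorophenyl in place of 3-chlorophenyl on a nitrogen on an aromatic ring. Among the compounds with values here, this is the same kind of exchange at the same place, and the only precedent for it is the step between compound 2 and compound 3, which stayed within the scatter. Within the data shown here, no measured step points to a direction here.

Compound 4 is therefore expected at 4000 nM, with a range of 1800 nM to 9000 nM. The expected step is a 1.1-fold higher number from compound 3 to compound 4 (0.05 log units; within the scatter), which is estimated to stay within the scatter.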

Compound 4, half-maximal inhibitory concentration: 5230 nM
Estimate against measurement, compound 4: 1.3-fold (0.12 log units) below; low and high end bracket the measured number.
By their numbers in this assay, from the lowest: compounds 3, 2, 4 and 1 (each within the scatter of the next, the first and the last beyond it).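

In this assay, the exchange to 2-fluorophenyl on a nitrogen on an aromatic ring gives a 1.5-fold higher number from compound 3 to compound 4 (0.16 log units; within the scatter) and, with 4-methoxyphenyl as the starting group, a 1.3-fold higher number from compound 2 to compound 4 (0.12 log units; within the scatter) in this series. For the compounds shown here, compounds 2, 3 and 4 therefore extend the earlier single comparison to three aryl groups at this position, and every pair among them lies within the scatter, with no compound among the three going against this. No measured evidence on the reason for this flat result is available.

As far as these compounds go, whether an amine or a carboxylic acid on this phenyl ring, or a longer chain in place of the aryl group, would shift the number beyond the scatter remains open. The compounds shown also leave open how far the number depends on the rest of the molecule when the aryl group is held constant.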